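A few compounds are considered here, and "the series" means these few. Any claim that something is new, unique, unknown or untested is made for them only; others in the source may bear on it.

Working notes on the sulfonamide pair. Compound 1 `O=C(O)c1ccc(S(=O)(=O)Nc2ccc(NS(=O)(=O)c3ccc(F)cc3)cc2)cc1` is read in an assay for inhibition of liver carboxylesterase 1 (Homo sapiens), read by spectrophotometry (on this read-out higher numbers stand for weaker inhibition and lower numbers for stronger inhibition), only as a limit, > 100000 nM. Compound 2 `O=S(=O)(Nc1ccc(NS(=O)(=O)c2ccc(Cl)cc2)c2ccccc12)c1ccc(Cl)cc1` likewise returns a limit in this assay, > 100000 nM. Among the compounds with values here, both values therefore sit at the limit of > 100000 nM in this assay, at which 2 of the 2 values shown sit, so no measured step is available, and nothing can be said of one compound ranking against the other.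

Compound 3 `COc1ccc(S(=O)(=O)Nc2ccc(NS(=O)(=O)c3ccc(F)cc3)cc2)cc1` differs from compound 1 by methoxy in place of carboxy on an aromatic carbon. With compound 1 known only as a limit, the step from compound 1 to compound 3 cannot be anchored; the expectation is a number no higher from compound 1 to compound 3 (the limit leaves the size open), that is, no change beyond the scatter. Compound 3 is expected at 100000 nM, with a range from 20000 nM to 500000 nM.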

Compound 3, inhibition constant: > 100000 nM
Compound 3: only a limit was reported (the forecaster's own chance of this, stated with the estimate: 60%); the middle value sits exactly at the limit.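

No step can be read from compound 1 to compound 3, as both compounds are reported only as limits: the limit of > 100000 nM in this assay, at which 3 of the 3 values shown sit. The compounds shown leave open whether any change to the shared core gives a readable value.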